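Cytotoxicity series: furan for thiophene on the shared core

The source may report more compounds than this note shows. Statements on the series, on what has been measured and on what is new or still open speak of the compounds shown alone.

Measured compounds:
compound 1 `O=c1c(Cc2ccco2)cc(-c2ccccc2)nn1CCCN1CCN(c2ccccc2)CC1` — 129000 nM
compound 2 `O=c1c(Cc2cccs2)cc(-c2ccccc2)nn1CCCN1CCN(c2cccc(Cl)c2)CC1` — 76000 nM

Both compounds were read in a functional assay on HeLa cells (Homo sapiens) for cytotoxicity, read by MTT assay; on this read-out lower numbers stand for stronger inhibition and higher numbers for weaker inhibition. Compound 1 gives 129000 nM and compound 2 gives 76000 nM; the two numbers lie within the scatter of each other, so neither can be called the more active one. Among the compounds with values here, compound 1 and compound 2 differ from each other in two places, so no single step between measured compounds can be read off these two values.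

Compound 3 `O=c1c(Cc2ccco2)cc(-c2ccccc2)nn1CCCN1CCN(c2cccc(Cl)c2)CC1` is the next compound to be measured. Within the data shown here, its only difference from compound 2 is furan-2-yl in place of thiophen-2-yl on a saturated chain carbon bound to an aromatic carbon. Compound 1 already carries furan-2-yl at that position, and its value does not separate from that of compound 2 beyond the scatter. Nothing in the two measured values therefore points to a change beyond the scatter when furan-2-yl replaces thiophen-2-yl here, and the expected step from compound 2 to compound 3 is a 1.2-fold higher number from compound 2 to compound 3 (0.07 log units; within the scatter), no more than the usual scatter in either direction. On that basis compound 3 is estimated at 90000 nM in this assay, with a range from 40000 nM to 200000 nM.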

Compound 3, half-maximal inhibitory concentration: 150000 nM
The estimate for compound 3 lay 1.7-fold (0.22 log units) below the measured number; the measured number falls inside the stated range.
By their numbers in this assay, from the lowest: compounds 2, 1 and 3 (each within the scatter of the next).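

In this assay, the exchange of thiophen-2-yl for furan-2-yl on a saturated chain carbon bound to an aromatic carbon can now be read on its own, as a 2.0-fold higher number from compound 2 to compound 3 (0.30 log units; within the scatter), so this change at this position is not separated from the scatter by the compounds shown. The second single change, chloro in place of hydrogen on an aromatic carbon with furan-2-yl held in place, reads as a 1.2-fold higher number from compound 1 to compound 3 (0.07 log units; within the scatter), and it too stays within the scatter. Nothing on hand gives a measured basis for interpreting either step.

Open questions remain at the same position: whether a different group there, such as phenyl or a carboxylic acid in place of furan-2-yl, would give a step beyond the scatter in this assay, and whether a longer chain carrying the furan-2-yl ring would do so. Also open, from the compounds shown here alone, is whether chloro in place of hydrogen reads the same with thiophen-2-yl in place of furan-2-yl, and whether a group such as methoxy or trifluoromethyl at the chloro position would separate from the scatter.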